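This account rests on a few compounds, and the source may have more. Where it says the series, first, only, none or still open, it means among the compounds named here.

Measured so far:
compound 1, `Cc1ccc(NC(=O)c2cc3ccccc3oc2=O)cc1`, gives 19500 nM in an in vitro assay on BTI-TN-5B1-4 cells for inhibition of Amine oxidase [flavin-containing] A (Homo sapiens), read by fluorescence; on this read-out higher numbers stand for weaker inhibition and lower numbers for stronger inhibition
compound 2, `CC(C)c1ccc(NC(=O)c2cc3ccccc3oc2=O)cc1`, gives 15100 nM in this assay

Within the data shown here, compound 2 holds the lower of these two numbers, yet the one step that reaches it, a 1.3-fold lower number from compound 1 to compound 2 (0.11 log units; within the scatter), lies within the scatter, so the two compounds cannot be told apart on these data; that step swaps isopropyl for methyl on an aromatic carbon. Compound 3, `O=C(Cl)c1ccc(NC(=O)c2cc3ccccc3oc2=O)cc1`, has not been measured. From compound 2 to compound 3 the change is a group of 3 heavy atoms (1 carbon, 1 oxygen, 1 chlorine; no ring) in place of a group of 3 heavy atoms (3 carbon; no ring), on an aromatic carbon, placed on an aromatic carbon of a six-membered aromatic ring of carbon only, para to a large group. Among the measured compounds shown here, the only measured step exchanges two groups of carbon only at this place and stays within the scatter; no measured step brings in oxygen or chlorine here, so no direction can be read from the data. Compound 3 is therefore expected to stay close to compound 2, the expected step being a 1.1-fold higher number from compound 2 to compound 3 (0.03 log units; within the scatter). Compound 3 is estimated at 16000 nM, with a range from 5000 nM to 50000 nM.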

Compound 3, half-maximal inhibitory concentration: 9670 nM
Compound 3: the middle estimate sits 1.7-fold (0.22 log units) above what was measured; measured number inside the range.
By their numbers in this assay, from the lowest: compounds 3, 2 and 1 (each within the scatter of the next).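

The group with a carbon, an oxygen and a chlorine brings the first hydrogen-bond acceptor and the first non-carbon atoms to this place on the ring. Even so, in this assay the steps of a 1.6-fold lower number from compound 2 to compound 3 (0.19 log units; within the scatter) and a 2.0-fold lower number from compound 1 to compound 3 (0.30 log units; within the scatter) both stay within the scatter, so on these data neither isopropyl nor methyl can be told apart from the new group, and three quite different groups at this place give numbers that cannot be separated. Nothing measured here bears on why these numbers fall as they do.

On these data alone, whether any group at this place can move the number beyond the scatter remains open. An amine, a carboxylic acid or a longer chain here would test that, and so would a change elsewhere on the shared core.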